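Hydantoin in Place of Thiazolidinedione in an Unfused Series

The source may report more compounds than this note shows. Statements on the series, on what has been measured and on what is new or still open speak of the compounds shown alone.

Of the compounds shown here, three have been measured in an assay on membranes from Chem-1 cells for displacement of a labelled ligand from prostaglandin E2 receptor EP3 subtype (Homo sapiens), read by scintillation counting, with a stated time of 2 h; a higher number here means a weaker inhibitor, a lower number a stronger inhibitor. Compound 1 `CCc1cccc2ccc(-c3ccc(C(/C=C4\OC(=O)NC4=O)(CC)CC)c(=O)[nH]3)cc12` gives 17 nM in this assay. Compound 2 `CC(C)C(c1ccc(-c2ccc3cccc(F)c3c2)[nH]c1=O)C1SC(=O)NC1=O` gives 25 nM in this assay, the second highest of the three numbers; its nearest neighbour is compound 1, within the scatter, and its furthest is compound 3 `CCC(/C=C1\OC(=O)NC1=O)(CC)c1ccc(-c2ccc3c(c2)OC(C)(C)CC3)[nH]c1=O`, which gives 2600 nM in this assay, a gap well beyond the scatter. No pair of these compounds differs in only one place, so no single-change step can be read from them.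

Compound 4 `CC(C)C(c1ccc(-c2ccc3cccc(F)c3c2)[nH]c1=O)C1C(=O)NC(=O)N1C` has not yet been measured. It differs from compound 2 by 3-methyl-2,5-dioxoimidazolidin-4-yl in place of 2,4-dioxo-1,3-thiazolidin-5-yl on a saturated chain carbon bound to an aromatic carbon and a saturated chain carbon. The imide hydrogen is kept in compound 4 while the ring atom count and acceptor count shift as described. Among the measured compounds shown here, nothing among the measured compounds shows what such a change does, so a small step, somewhat towards a higher number, is expected, though within or only just beyond the scatter. The estimated step of a 2.4-fold higher number from compound 2 to compound 4 (0.38 log units; beyond the scatter) therefore stays modest. Compound 4 is expected to give about 60 nM in this assay, with a range from 15 nM to 300 nM.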

Compound 4, inhibition constant: 46 nM
Estimate against measurement, compound 4: 1.3-fold (0.12 log units) above, within the range that was stated.
By their numbers in this assay, from the lowest: compounds 1, 2 and 4 (each within the scatter of the next, the first and the last beyond it); then compound 3.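

Among the compounds shown here, the change of 2,4-dioxo-1,3-thiazolidin-5-yl to 3-methyl-2,5-dioxoimidazolidin-4-yl gives the first single-change step in the set, and in this assay it is a 1.8-fold higher number from compound 2 to compound 4 (0.26 log units; within the scatter). On this saturated chain carbon, with the rest of compound 2 kept, the sulfur-containing ring can therefore be exchanged for the nitrogen-containing, methylated ring without a step beyond the scatter. No measurement of any property of these compounds bears on the size of this step.

Going by these compounds, the exchange alters the ring and adds the methyl group in a single step, so what each contributes remains open, and the unmethylated 2,5-dioxoimidazolidin-4-yl ring would separate the two. Also open, on these data alone, is how a carboxylic acid or an N-ethyl group would fare at this place, and whether the exchange would give a similar step on another core.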